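The compounds below may be only part of what the source reports. "The series", "measured", "known", "first", "only" and "open" are said of these compounds alone.

Among the compounds with values here, compound 1 `N#CC1=C(NC(=O)c2ccccc2)N(c2ccc(S(N)(=O)=O)cc2)C2=C(C(=O)CCC2)C1c1ccc(Cl)cc1Cl` gives 70% in a functional assay on Ehrlich cells (Mus musculus) for cytotoxicity, read by trypan blue exclusion, with a stated time of 2 h, tested at 50 ug/mL (on this read-out higher numbers stand for a stronger effect at the one concentration tested and lower numbers for a weaker effect), the lowest of the two numbers measured so far, while compound 2 `COc1cc(C(=O)NC2=C(C#N)C(c3ccc(Cl)cc3Cl)C3=C(CCCC3=O)N2c2ccc(S(N)(=O)=O)cc2)cc(OC)c1OC` gives 95%. Within the data shown here, the single measured step, a number 25 percentage points higher from compound 1 to compound 2 (beyond the scatter), was a modest rise. Compound 3 `CN(C)c1ccc(/C=N/C2=C(C#N)C(c3ccc(Cl)cc3Cl)C3=C(CCCC3=O)N2c2ccc(S(N)(=O)=O)cc2)cc1` differs from compound 1 by a group of 11 heavy atoms (9 carbon, 2 nitrogen; one six-membered aromatic ring of carbon only) in place of a group of 9 heavy atoms (7 carbon, 1 nitrogen, 1 oxygen; one six-membered aromatic ring of carbon only), on a double-bonded ring carbon. Among the measured compounds shown here, no measured step replaces the benzamido group itself; the one measured step altered only the ring attached to its carbonyl carbon, so it bears on this change only loosely. Compound 3 is therefore expected to give about 72% in this assay, within 45% to 95%. The expected step is a number 2 percentage points higher from compound 1 to compound 3 (within the scatter), not beyond the scatter.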

Compound 3, a percentage reported as activity, at one concentration (the size of the read-out at that concentration, not a potency): 30%
For compound 3 the middle estimate is 42 percentage points above the measured one; measured number below the stated range.
By their numbers in this assay, from the lowest: compound 3; then compound 1; then compound 2.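

In this assay, the double-bonded ring carbon proves sensitive to replacing the whole benzamido group: the result is a number 40 percentage points lower from compound 1 to compound 3 (beyond the scatter). The earlier step altered only the ring on the carbonyl carbon and raised the number, whereas this change removes the amide link and lowers it. Nothing measured here explains the fall.

The compounds shown leave open whether the amide link or the ring substitution matters more, as compound 3 differs from compound 1 in both. From the compounds shown here alone, how a free amine or an acetamido group on this carbon would read also remains open.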